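This account rests on a few compounds, and the source may have more. Where it says the series, first, only, none or still open, it means among the compounds named here.

Measured compounds:

compound 1, `O=C(Nc1ccccc1)c1cccc(/C=C2\CC(=O)N(c3ccccc3)C2=O)c1`: > 100000 nM, a limit of the assay.

compound 2, `CCCCCN1C(=O)C/C(=C\c2cccc(C(=O)Nc3cccc(CC)c3)c2)C1=O`: 75300 nM.

compound 3, `COc1cc(NC(=O)c2cccc(/C=C3\CC(=O)N(c4ccccc4)C3=O)c2)cc(OC)c1OC`: > 100000 nM, again a limit.

All three were read in an ADME assay on HCT-116 cells (Homo sapiens) for cytotoxicity, read by MTT assay, with a stated time of 72 h; on this read-out lower numbers stand for stronger inhibition and higher numbers for weaker inhibition. Compound 1 stands at the limit rather than at a number, and it shares that position with compound 3, so that the limit of > 100000 nM in this assay, at which 2 of the 3 values shown sit, describes two of the three results. For the measured compounds named here, compound 2 is the only compound with a numeric result, and that result lies close to the limit as well. Going by the values given here, no pair of measured compounds differs in a single place, so there is no measured step from which a trend could be carried over.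

Compound 4, `O=C(Nc1ccc(Cl)cc1)c1cccc(/C=C2\CC(=O)N(c3ccccc3)C2=O)c1`, is not yet measured. Against compound 1 the change is chloro in place of hydrogen on an aromatic carbon.

Among the compounds with values here, with the shared core giving only limits or a near-limit number for every compound so far, the step from compound 1 to compound 4 is expected to show no change beyond the scatter, a number no higher from compound 1 to compound 4 (the limit leaves the size open). For compound 4 the estimate in this assay is 100000 nM, with a range from 40000 nM to 300000 nM, and a reported limit instead of a number is the more likely outcome.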

Compound 4, half-maximal inhibitory concentration: > 100000 nM
Compound 4: no number, only a limit (the forecaster's own chance of this, stated with the estimate: 70%); the middle value lies on the limit itself.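

Compound 1 and compound 4 both give a limit rather than a number in this assay, so the step between them cannot be read: the limit of > 100000 nM in this assay, at which 3 of the 4 values shown sit. Left open is whether chloro in place of hydrogen changes the read-out in any compound of this series that gives a number.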